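Swapping the Methoxy for a Methylpiperidine Ring

A few compounds are considered here, and "the series" means these few. Any claim that something is new, unique, unknown or untested is made for them only; others in the source may bear on it.

Compound 1 `O=C(NCCCCc1ccccc1)n1cc(-c2ccccc2)oc1=O` gives 90 nM in an assay on isolated protein for inhibition of acid ceramidase (Homo sapiens), read by LC-MS, with a stated time of 1 h; on this read-out lower numbers stand for stronger inhibition and higher numbers for weaker inhibition. Compound 2 `COc1cccc(-c2cn(C(=O)NCCCCc3ccccc3)c(=O)o2)c1` gives 341 nM, the highest of the three numbers seen so far, and compound 3 `COc1ccccc1-c1cn(C(=O)NCCCCc2ccccc2)c(=O)o1` gives 177 nM. The measured steps show a 3.8-fold higher number from compound 1 to compound 2 (0.58 log units; beyond the scatter) and a 1.9-fold lower number from compound 2 to compound 3 (0.28 log units; within the scatter), while a 2.0-fold higher number from compound 1 to compound 3 (0.29 log units; within the scatter). Compound 4 `CN1CCC(c2cccc(-c3cn(C(=O)NCCCCc4ccccc4)c(=O)o3)c2)CC1` differs from compound 2 by 1-methylpiperidin-4-yl in place of methoxy on an aromatic carbon. Going by the values given here, the steps that bear on this position only add or move a methoxy, so they speak only loosely to a change of this kind; no step with a ring like this one has been measured. The expected outcome in this assay is therefore uncertain, with no clear direction beyond the scatter. Compound 4 is estimated at 300 nM, between 70 nM and 1300 nM, which would mean an expected step of a 1.1-fold lower number from compound 2 to compound 4 (0.06 log units; within the scatter).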

Compound 4, half-maximal inhibitory concentration: 153 nM
Beside the measured number, compound 4's estimate is 2.0-fold (0.29 log units) above it, and the stated range covers the measured number.
By their numbers in this assay, from the lowest: compounds 1, 4, 3 and 2 (each within the scatter of the next, the first and the last beyond it).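

In this assay, the larger ring does better here than methoxy: a 2.2-fold lower number from compound 2 to compound 4 (0.35 log units; beyond the scatter) is a modest step beyond the scatter. Against plain hydrogen, a 1.7-fold higher number from compound 1 to compound 4 (0.23 log units; within the scatter) stays within the scatter, so this place on the aromatic ring accepts a far bulkier group than methoxy without a clear loss. No measurement shown explains why the ring outperforms methoxy. Still open, from the compounds shown here alone, is which part of 1-methylpiperidin-4-yl matters, since neither a piperidine ring lacking the methyl nor a morpholine ring appears here. A carboxylic acid at this place is equally untested among these compounds.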